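A few compounds are considered here, and "the series" means these few. Any claim that something is new, unique, unknown or untested is made for them only; others in the source may bear on it.

Measured compounds:
compound 1, `C=C(Br)C(=O)Nc1cccc(-c2cn3nc(-c4ccc(OC)c(OC)c4)sc3n2)c1`, 42 nM
compound 2, `COc1ccc(-c2csc3nc(-c4cccc(N)c4)cn23)cc1`, 19000 nM
compound 3, `CCc1ccc(-c2nn3cc(-c4cccc(N)c4)nc3s2)cc1`, 6000 nM

In a functional assay on L1210 cells (Mus musculus) for inhibition, read by cell counting, with a stated time of 2 days (a higher number here means a weaker inhibitor, a lower number a stronger inhibitor), compound 3 stands second highest of the three numbers. Its nearest neighbour is compound 2, whose value of 19000 nM lies beyond the usual scatter above it; compound 1, at 42 nM, lies far below it. Compound 4, `COc1ccc(-c2nn3cc(-c4cccc(N)c4)nc3s2)cc1`, has not yet been measured. It differs from compound 3 by one change: methoxy in place of ethyl on an aromatic carbon. Going by the values given here, no pair of measured compounds shows this same exchange on a shared core, so there is no step to lean on. Compound 2 carries the same methoxy group on a different core and gives 19000 nM, a weaker reading than compound 3. Compound 4 is therefore expected to come out somewhat weaker than compound 3, with a step of a 1.7-fold higher number from compound 3 to compound 4 (0.22 log units; within the scatter), and an estimated value of 10000 nM, in the range 3000 nM to 30000 nM.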

Compound 4, half-maximal inhibitory concentration: >= 250000 nM
Compound 4: only a limit was reported; the forecaster's own chance of this, stated with the estimate: 5%; middle value at least 25-fold (1.39 log units) from the limit.
By their numbers in this assay, from the lowest: compound 1; then compound 3; then compound 2. At a limit, above all of these: compound 4.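

In this assay, methoxy in place of ethyl on this aromatic carbon, para to a large group, is far from a neutral exchange on the shared core: the data show an at least 41-fold higher number from compound 3 to compound 4 (1.61 log units; beyond the scatter). The exchange leaves the heavy-atom count unchanged and adds one hydrogen-bond acceptor, yet this single place clearly governs the reading. The result for compound 4 is a limit of the assay, not an exact number: the limit of >= 250000 nM in this assay, at which 1 of the 4 values shown sits.

On these data alone, the true size of the step therefore remains open. Also open, as far as these compounds go, is whether a longer chain, such as propyl, or an amine at this place would read like ethyl or like methoxy.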